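A few compounds are considered here, and "the series" means these few. Any claim that something is new, unique, unknown or untested is made for them only; others in the source may bear on it.

In a functional assay on CCRF-CEM cells (Homo sapiens), read by MTT assay, with a stated time of 72 h (a higher number here means a weaker inhibitor, a lower number a stronger inhibitor), compound 1 `CNc1ncnc2c1c(-c1ccco1)cn2[C@@H]1O[C@H](CO)[C@@H](O)[C@H]1O`, with furan-2-yl on the shared core, gives 180 nM. Compound 2 `CNc1ncnc2c1c(-c1ccccc1)cn2[C@@H]1O[C@H](CO)[C@@H](O)[C@H]1O` gives > 20000 nM, which is a limit of the assay and not a number. Compound 3 `CNc1ncnc2c1c(I)cn2[C@@H]1O[C@H](CO)[C@@H](O)[C@H]1O` has not yet been measured, and it differs from compound 2 by iodo in place of phenyl on an aromatic carbon. Among the compounds with values here, the only measured step that bears on this change is the arrival of phenyl in place of furan-2-yl on that same carbon, an at least 110-fold higher number from compound 1 to compound 2 (2.04 log units; beyond the scatter), a large step. Within the data shown here, a sizeable move to a lower number is therefore expected in this assay when phenyl leaves, although no measured compound yet carries iodo there. The expected change is an at least 10-fold lower number from compound 2 to compound 3 (1.00 log units; beyond the scatter). For compound 3 the estimated value is 2000 nM, with an expected range of 150 nM to 20000 nM.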

Compound 3, half-maximal inhibitory concentration: > 100000 nM
Compound 3 was reported as a limit (the forecaster's own chance of this, stated with the estimate: 25%); middle value at least 50-fold (1.69 log units) away from the limit.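

In this assay compound 3 gives > 100000 nM, which is a limit of the assay and not a number. Iodo in place of furan-2-yl on this aromatic carbon gives an at least 550-fold higher number from compound 1 to compound 3 (2.74 log units; beyond the scatter), so a single iodine atom ends at a limit just as a six-membered aromatic ring of carbon only does, and among the compounds shown the low number belongs to the furan-2-yl group alone. The step between compound 2 and compound 3 cannot be read, as both values are limits.

The compounds shown leave open whether the low number needs furan-2-yl itself or would also come with another five-membered aromatic ring, such as thiophen-2-yl, or with a methyl or an amine on this carbon. They also leave open what numbers lie behind the two limits.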